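This account rests on a few compounds, and the source may have more. Where it says the series, first, only, none or still open, it means among the compounds named here.

Compound 1 `CC(C)(CCC/C=C(\c1ccccc1)c1cccnc1)C(=O)O`: 21 nM
Compound 2 `CC(C)(CCC/C=C(/c1ccccc1)c1cccnc1)C(=O)O`: 30 nM

In an assay (Equus caballus) for inhibition of Thromboxane-A synthase (Homo sapiens), using microsomes (on this read-out higher numbers stand for weaker inhibition and lower numbers for stronger inhibition), compound 1 gives 21 nM, the lowest of the two numbers shown. Among the measured compounds shown here, compound 2 gives 30 nM, and the only measured step, a 1.4-fold higher number from compound 1 to compound 2 (0.15 log units; within the scatter), stays within the scatter; the two compounds differ solely in the configuration drawn at the double bond (the fact that compounds 1 and 2 differ only in the configuration as drawn), so nothing about the chain or the acid group has yet been tested.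

Compound 3 `O=C(O)CCC/C=C(\c1ccccc1)c1cccnc1` has not been measured. It differs from compound 1 by carboxy in place of 1-carboxy-1-methylethyl on a saturated chain carbon, three bonds along the chain from a double-bonded chain carbon. For the measured compounds named here, no measured step touches this part of the molecule, so the measured pair gives no direct guide; the shared core of compound 1 is kept, while the acid-bearing chain is shortened and loses its two methyl groups. A moderate weakening is expected rather than none. Compound 3 is expected to give about 60 nM in this assay, with a range from 20 nM to 200 nM. This expectation amounts to a 2.9-fold higher number from compound 1 to compound 3 (0.46 log units; beyond the scatter).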

Compound 3, half-maximal inhibitory concentration: 30 nM
Estimate against measurement, compound 3: 2.0-fold (0.30 log units) above, within the range that was stated.
By their numbers in this assay, from the lowest: compounds 1, 2 and 3 (each within the scatter of the next).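

Swapping the 1-carboxy-1-methylethyl group for carboxy on this saturated chain carbon, in this assay, gives a 1.4-fold higher number from compound 1 to compound 3 (0.15 log units; within the scatter). Among the compounds shown here, compounds 1 and 2 differed only at the double bond, so this is the first measured change to the acid-bearing part of the chain, and it shows that the smaller carboxy group and the larger group cannot be told apart in this assay. Nothing measured here gives a reason for this result.

All the compounds shown carry a carboxylic acid, so it remains open what an amide in its place would do, or what a longer chain would do. From the compounds shown here alone, it also remains open whether the double-bond configuration would still make so little difference with the carboxy group in place.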